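A few compounds are considered here, and "the series" means these few. Any claim that something is new, unique, unknown or untested is made for them only; others in the source may bear on it.

Compound 1 `O=C(CSC(=S)N[C@H]1CCOC1=O)Nc1ccc(Cl)cc1`: > 128000 nM
Compound 2 `Cc1cccc(NC(=O)CSC(=S)N[C@H]2CCOC2=O)c1C`: > 128000 nM
Compound 3 `O=C(CSC(=S)N[C@H]1CCOC1=O)Nc1ccc(Cl)cc1Cl`: > 128000 nM

In a functional assay on EC9706 cells (Homo sapiens) for cytotoxicity, read by MTT assay, with a stated time of 72 h (on this read-out lower numbers stand for stronger inhibition and higher numbers for weaker inhibition), compound 1 gives > 128000 nM, which is a limit of the assay and not a number. Compound 2 likewise gives > 128000 nM, again a limit. Compound 3 gives > 128000 nM, also a limit. All three values therefore sit at the limit of > 128000 nM in this assay, at which 3 of the 3 values shown sit, so compound 1 stands nowhere on a scale of numbers but only at that limit, alongside compound 2 and compound 3. For the measured compounds named here, the one step between compounds that differ in a single place, a step that the two limits leave unreadable from compound 1 to compound 3, is consequently unreadable: the two limits allow no statement of its size or direction.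

Compound 4 `CCCCc1ccc(NC(=O)CSC(=S)N[C@H]2CCOC2=O)cc1` has not yet been measured in this assay. It differs from compound 1 by butyl in place of chloro on an aromatic carbon. Going by the values given here, the only measured step that touches the same position is the one from compound 1 to compound 3, and that step cannot be read, so no measured step gives a size or direction for the exchange of chloro for butyl.

With nothing beyond three limits to rest on, compound 4 is expected to give 128000 nM, with a range from 50000 nM to 400000 nM. The step of a number no higher from compound 1 to compound 4 (the limit leaves the size open) is thus estimated to be none beyond the scatter, and a further limit rather than a number is the more likely outcome.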

Compound 4, half-maximal inhibitory concentration: 44200 nM
Beside the measured number, compound 4's estimate is 2.9-fold (0.46 log units) above it; measured number outside the range, below it.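

In this assay, for the compounds shown here, butyl in place of chloro on an aromatic carbon, para to a large group, gives an at least 2.8-fold lower number from compound 1 to compound 4 (0.46 log units; beyond the scatter), the first step that can be read; the earlier step could not be read, and the earlier values gave no sign that this position could change the read-out at all. The position is now shown to respond to the group it carries, with four carbon atoms entering where one chlorine leaves and no ring, hydrogen-bond donor, hydrogen-bond acceptor or net charge on either side of the exchange. The end of the step at compound 1 is a limit and not a number, so its full size stays open: the limit of > 128000 nM in this assay, at which 3 of the 4 values shown sit.

From the compounds shown here alone, what a shorter ethyl chain, a longer hexyl chain or an amine would give on this same carbon stays open, so a single butyl result cannot tell whether the read-out follows chain length. Also open, going by these compounds, is whether butyl would have the same effect alongside a second ring substituent, such as the additional chloro of compound 3.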